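The source may report more compounds than this note shows. Statements on the series, on what has been measured and on what is new or still open speak of the compounds shown alone.

Series notes, values from a physicochemical assay for solubility; a higher number here means a more soluble compound, a lower number a less soluble compound:

- compound 1 `CS(=O)(=O)c1ccc(-n2nc(C(F)(F)F)cc2-c2ccccc2)nc1`: 50 ug/mL
- compound 2 `CC(C)(C)CNc1cc(C(F)(F)F)nn1-c1ccc(S(C)(=O)=O)cn1`: "not determined" (no result reported)

The next compound to be measured is compound 3 `CS(=O)(=O)c1ccc(-n2nc(C(F)(F)F)cc2OC2CCCC2)nc1`, and the notes follow it from compound 2. Compound 2 has no place on the scale: in this assay compound 2 stands at "not determined" (no result reported), so it offers no single number to start from. The structural change is cyclopentyloxy in place of neopentylamino on an aromatic carbon, which puts cyclopentyloxy in place of neopentylamino on an aromatic carbon. Among the measured compounds shown here, no step between measured compounds exists, so nothing measured shows what a change at this place does to the read-out. For the measured compounds named here, the only number available is that of compound 1 at 50 ug/mL, and one number gives a rough level rather than a trend. Against that level, no step beyond the usual scatter is expected in this assay, with a slight lean towards the lower side and a wide margin for the uncertainty. For compound 3 the expected value is 30 ug/mL, with an estimated range of 8 ug/mL to 100 ug/mL.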

Compound 3, solubility: 50 ug/mL
Estimate against measurement, compound 3: 1.7-fold (0.22 log units) below, and the stated range covers the measured number.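

In this assay, among the compounds shown here, the first readable step at this position is no change at the digits printed from compound 1 to compound 3 (within the scatter), so the exchange of phenyl for cyclopentyloxy on an aromatic carbon of the shared core gives no step beyond the scatter in this one pair. Before this result, the series held a single number and no step, whereas there is now one direct comparison at this position, between an aromatic ring and a non-aromatic carbon ring attached through oxygen. Compound 2 carries no number, so its step to compound 3 cannot be read, and no measurement shown accounts for the outcome of the readable step.

With one readable step, these compounds leave open whether the absence of a step beyond the scatter extends to other groups on this aromatic carbon, and neopentylamino remains unplaced on the scale. A morpholine, a carboxylic acid or a longer ether chain at this position would test whether the read-out moves beyond the scatter when the group differs more from phenyl and cyclopentyloxy.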